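The source may report more compounds than this note shows. Statements on the series, on what has been measured and on what is new or still open speak of the compounds shown alone.

Compound 2, `CCC/C=C/C(=O)O[C@H](CC=C(C)C)C1=CC(=O)c2c(O)ccc(O)c2C1=O`, carries an ester on the shared core; in an assay on HeLa cells for inhibition of DNA topoisomerase 1 (Homo sapiens) (on this read-out higher numbers stand for weaker inhibition and lower numbers for stronger inhibition), compound 2 gives 153000 nM. Among the compounds with values here, compound 1, `CC(C)=CC[C@@H](OC(=O)CCl)C1=CC(=O)c2c(O)ccc(O)c2C1=O`, gives 137000 nM in this assay, and the only step measured so far, a 1.1-fold higher number from compound 1 to compound 2 (0.05 log units; within the scatter), leaves both compounds within the scatter of each other. Compound 3, `C=CCC/C=C/C(=O)O[C@H](CC=C(C)C)C1=CC(=O)c2c(O)ccc(O)c2C1=O`, differs from compound 2 by vinyl in place of methyl on a saturated chain carbon, two bonds along the chain from a double-bonded chain carbon. Because the step of a 1.1-fold higher number from compound 1 to compound 2 (0.05 log units; within the scatter) changed the chain of the ester without moving the number beyond the scatter, a similar small extension is expected to do the same. The expected step is a 1.0-fold lower number from compound 2 to compound 3 (0.01 log units; within the scatter). Compound 3 is therefore estimated at 150000 nM, in a range from 70000 nM to 320000 nM.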

Compound 3, half-maximal inhibitory concentration: 126000 nM
Compound 3: the middle estimate sits 1.2-fold (0.08 log units) above what was measured; measured number inside the range.
By their numbers in this assay, from the lowest: compounds 3, 1 and 2 (each within the scatter of the next).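

Putting vinyl in place of methyl on a saturated chain carbon, two bonds along the chain from a double-bonded chain carbon, gives a step that stays within the scatter in this assay (a 1.2-fold lower number from compound 2 to compound 3 (0.08 log units; within the scatter)). Hexa-1,5-dien-1-yl in place of chloromethyl on a carbonyl carbon also stays within the scatter (a 1.1-fold lower number from compound 1 to compound 3 (0.04 log units; within the scatter)), so these three esters cannot be told apart here. Nothing available explains this flat result.

As far as these compounds go, whether an amine or a carboxylic acid on this chain would move the number beyond the scatter remains open. So does the effect of a much longer chain.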